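Swapping the bromophenyl sulfonyl group for a bithiophene

The compounds below may be only part of what the source reports. "The series", "measured", "known", "first", "only" and "open" are said of these compounds alone.

Among the measured compounds shown here, compound 1 `CCN(C/C=C/C#CC(C)(C)C)Cc1cccc(OCCN(C)S(=O)(=O)c2ccc(Br)cc2)c1` gives 330 nM in a functional assay on HepG2 cells for inhibition of squalene monooxygenase (Homo sapiens) (a lower number here means a stronger inhibitor, a higher number a weaker inhibitor), the higher of the two numbers measured so far. Compound 2 `CCN(C/C=C/C#CC(C)(C)C)Cc1cccc(OCCN(C2CC2)S(=O)(=O)c2cccs2)c1` gives 230 nM in this assay, a reading that the two values show to lie within the usual scatter of compound 1. Compound 3 `CCN(C/C=C/C#CC(C)(C)C)Cc1cccc(OCCN(C)S(=O)(=O)c2cc(-c3ccsc3)cs2)c1` carries 4-(thiophen-3-yl)thiophen-2-yl in place of 4-bromophenyl on a sulfonyl sulfur. For the measured compounds named here, with no comparable step measured, the change from compound 1 to compound 3 is expected to give a small shift toward a lower number, a 1.7-fold lower number from compound 1 to compound 3 (0.22 log units; within the scatter), at the edge of the scatter. Compound 3 is therefore estimated at 200 nM, with a range from 60 nM to 700 nM.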

Compound 3, half-maximal inhibitory concentration: 90 nM
The estimate for compound 3 lay 2.2-fold (0.35 log units) above the measured number; measured number inside the range.
By their numbers in this assay, from the lowest: compound 3; then compounds 2 and 1 (each within the scatter of the next).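

Among the compounds shown here, on the sulfonyl sulfur, whose other neighbour is the sulfonamide nitrogen, 4-bromophenyl proves replaceable: in this assay, 4-(thiophen-3-yl)thiophen-2-yl gives a 3.7-fold lower number from compound 1 to compound 3 (0.56 log units; beyond the scatter), the only step here beyond the scatter. Two five-membered aromatic rings are thus tolerated where one six-membered aromatic ring stood. Nothing available accounts for the gain.

Compound 2 differs from compound 1 in two places, so it cannot show what a single thiophene ring contributes at this position. On these data alone, whether a biphenyl-4-yl group would match the bithiophene remains open.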